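Working notes on the triazole amide series: compound 4

A few compounds are considered here, and "the series" means these few. Any claim that something is new, unique, unknown or untested is made for them only; others in the source may bear on it.

In a functional assay on HT-29 cells (Homo sapiens) for cytotoxicity, read by MTT assay, with a stated time of 72 h (on this read-out higher numbers stand for weaker inhibition and lower numbers for stronger inhibition), compound 2 `COc1cc2c(Oc3ccc(NC(=O)c4cn(-c5ccccc5F)nn4)cc3F)ccnc2cc1OCCCN1CCN(C)CC1` gives 300 nM, compound 1 `COc1cc2c(Oc3ccc(NC(=O)c4cn(-c5ccc(F)c(F)c5)nn4)cc3F)ccnc2cc1OCCCN1CCC(C)CC1` gives 810 nM and compound 3 `COc1cc2c(Oc3ccc(NC(=O)c4cn(-c5ccccc5C)nn4)cc3F)ccnc2cc1OCCCN1CCN(C)CC1` gives 1430 nM. Compound 3 gives a higher number than compound 2, beyond the scatter, and lies within the scatter of compound 1. Compound 4 `COc1cc2c(Oc3ccc(NC(=O)c4cn(-c5ccc(F)c(F)c5)nn4)cc3F)ccnc2cc1OCCCN1CCN(C)CC1` differs from compound 3 by 3,4-difluorophenyl in place of 2-methylphenyl on an aromatic nitrogen. Among the measured compounds shown here, the only measured step that bears on this is a 4.8-fold higher number from compound 2 to compound 3 (0.68 log units; beyond the scatter); taken in reverse, it points to a lower number on returning from methyl to fluorine. Compound 1 also carries the 3,4-difluorophenyl but differs elsewhere, and its number sits between those of compound 2 and compound 3. A step of a 3.2-fold lower number from compound 3 to compound 4 (0.50 log units; beyond the scatter) is therefore expected. Compound 4 is expected at 450 nM, with a range of 200 nM to 1000 nM.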

Compound 4, half-maximal inhibitory concentration: 430 nM
Compound 4: the middle estimate sits 1.0-fold (0.02 log units) above what was measured; the measured number falls inside the stated range.
By their numbers in this assay, from the lowest: compounds 2, 4, 1 and 3 (each within the scatter of the next, the first and the last beyond it).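

In this assay, 3,4-difluorophenyl on the aromatic nitrogen, with 4-methylpiperazin-1-yl held, recovers most of what 2-methylphenyl gave up (a 3.3-fold lower number from compound 3 to compound 4 (0.52 log units; beyond the scatter)) and cannot be told apart from 2-fluorophenyl (a 1.4-fold higher number from compound 2 to compound 4 (0.16 log units; within the scatter)). With 3,4-difluorophenyl held, 4-methylpiperazin-1-yl and 4-methylpiperidin-1-yl also cannot be told apart (a 1.9-fold lower number from compound 1 to compound 4 (0.28 log units; within the scatter)). Nothing at hand accounts for these steps.

Open, from the compounds shown here alone, is whether unsubstituted phenyl or 4-methoxyphenyl on the aromatic nitrogen would stand with the fluorinated groups or with 2-methylphenyl, and how morpholine would compare with 4-methylpiperazin-1-yl.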